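Removing a methyl from a methoxy group on an aryl pyrazole

The compounds below may be only part of what the source reports. "The series", "measured", "known", "first", "only" and "open" are said of these compounds alone.

Measured compounds:
compound 1, `COc1cc(C)cc(-c2c(-c3ccnc(-c4ccc(N(C)C)cc4)c3)cnn2CC#N)c1`, -3%
compound 2, `COc1cc(C)cc(-c2nn(CC#N)cc2-c2ccnc(-c3ccc(N(C)C)cc3)c2)c1`, 101%
compound 3, `COc1cc(C)cc(-c2nn(CC#N)cc2-c2ccc(-c3cccc(C(C)=O)c3)nc2)c1`, 92%

Three compounds built on the shared core were tested in a functional assay on IGROV-1 cells (Homo sapiens) for cytotoxicity, read by sulforhodamine B assay, with a stated time of 48 h, tested at 0.01 uM; a higher number here means a weaker effect of the compound at the concentration tested, a lower number a stronger effect. Compound 1 gives -3%, compound 2 gives 101% and compound 3 gives 92%. On these numbers compound 2 stands highest of the three. Its nearest neighbour is compound 3, whose value lies within the usual scatter of the same measurement, so no order between the two can be read. Within the data shown here, compound 1 lies far below compound 2, beyond the scatter, and no single-point step is recorded between any pair, so their values can only be set side by side.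

The account now turns from compound 2 to compound 4, `Cc1cc(O)cc(-c2nn(CC#N)cc2-c2ccnc(-c3ccc(N(C)C)cc3)c2)c1`, not yet measured in this assay. The change is small: hydrogen in place of methyl on an oxygen on an aromatic ring, or, read one bond further out, methoxy to hydroxy on the 3-methoxy-5-methylphenyl ring, giving 3-hydroxy-5-methylphenyl. Among the measured compounds shown here, no measured pair shows the effect of such a change here. One methyl less on an oxygen is expected to move the value little, so the step of a number 6 percentage points lower from compound 2 to compound 4 (within the scatter) is estimated to stay within the scatter, with no clear direction. Compound 4 is therefore expected to give about 95%, between 75% and 108%.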

Compound 4, a percentage reported as activity, at one concentration (the size of the read-out at that concentration, not a potency): 94%
Compound 4: the middle estimate sits 1 percentage points above what was measured; the range from low to high includes it.
By their numbers in this assay, from the lowest: compound 1; then compounds 3, 4 and 2 (each within the scatter of the next).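

In this assay, among these compounds, the change from methoxy to hydroxy on the 3-methoxy-5-methylphenyl ring comes with a number 7 percentage points lower from compound 2 to compound 4 (within the scatter), the first step that isolates a change in a single place. At this position, then, hydrogen in place of methyl on an oxygen on an aromatic ring leaves the read-out indistinguishable from that of the parent at the one concentration tested, and no direction of change can be read from it. The data shown offer no explanation of this outcome, and nothing here tells what the methyl or the hydrogen on that oxygen contributes.

The compounds shown leave open whether a longer chain on that oxygen, such as ethoxy or propoxy, or an amine in place of the hydroxy group would also leave the read-out where it is. Also open, on these data alone, is whether the same step would hold on the core of compound 1, which gives -3%, where the read-out has far more room to rise than it has for compound 2 at 101%.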